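The source may hold more compounds than are shown below. What is called first, only, known or untested is meant among the compounds shown, and "the series" means these compounds.

Compound 1 `Cc1ccc2nc(-c3ccccc3N(C)C)[nH]c(=O)c2c1` and compound 2 `Cc1ccc2nc(-c3ccccc3C(F)(F)F)[nH]c(=O)c2c1` share one core. In an assay on isolated protein for inhibition of DNA topoisomerase 1 (Homo sapiens), with a stated time of 30 min, tested at 20 uM (on this read-out higher numbers stand for a stronger effect at the one concentration tested and lower numbers for a weaker effect), compound 1 gives 21.1% and compound 2 gives 21.1%; the step of no change at the digits printed from compound 1 to compound 2 (within the scatter) lies within the scatter, so compound 2 stands level with compound 1. Compound 3 `CCN(CC)c1ccc2nc(-c3ccccc3C(F)(F)F)[nH]c(=O)c2c1` differs from compound 2 by diethylamino in place of methyl on an aromatic carbon. Among the measured compounds shown here, no measured step touches this place; the one step known, no change at the digits printed from compound 1 to compound 2 (within the scatter), concerns a different group and was flat. The step of a number 0.1 percentage points lower from compound 2 to compound 3 (within the scatter) is therefore expected to stay within the scatter. Compound 3 is estimated at 21% in this assay, between 5% and 40%.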

Compound 3, a percentage reported as inhibition, at one concentration (the size of the read-out at that concentration, not a potency): 13.3%
Beside the measured number, compound 3's estimate is 7.7 percentage points above it, and the stated range covers the measured number.
By their numbers in this assay, from the lowest: compounds 3, 1 and 2 (each within the scatter of the next).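

In this assay, among the compounds shown here, diethylamino in place of methyl on this aromatic carbon gives a number 7.8 percentage points lower from compound 2 to compound 3 (within the scatter) and so adds a first reading at this position, which the earlier pair did not touch. Going from 1 heavy atom to 5 heavy atoms and adding 1 hydrogen-bond acceptor here does not carry the read-out beyond the scatter. No available evidence bears on this result.

As far as these compounds go, whether a carboxylic acid or a morpholine at this aromatic carbon would also stay within the scatter remains open. A single concentration also leaves the potency of these compounds open.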